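A few compounds are considered here, and "the series" means these few. Any claim that something is new, unique, unknown or untested is made for them only; others in the source may bear on it.

In a functional assay on RT-112 cells (Homo sapiens) for antiproliferative activity, read by MTT assay, with a stated time of 72 h (on this read-out higher numbers stand for weaker inhibition of growth and lower numbers for stronger inhibition of growth), compound 1 (`COc1cc(Nc2ncnc3c(NC(=O)Nc4ccc5c(c4)OCCO5)cccc23)cc(OC)c1`) gives 2750 nM, compound 2 (`COc1cc(Nc2ncnc3c(NC(=O)Nc4cc(C)cc(C)c4)cccc23)cc(OC)c1`) gives 10100 nM, and compound 3 (`COc1cc(Nc2ncnc3c(NC(=O)Nc4ccc(Cl)cc4Cl)cccc23)cc(OC)c1`) gives 3060 nM. All three share one core and differ only in the group on an amide-type nitrogen. Compound 3 belongs to the lower pair of these numbers: a 1.1-fold higher number from compound 1 to compound 3 (0.05 log units; within the scatter) lies within the scatter, while a 3.3-fold lower number from compound 2 to compound 3 (0.52 log units; beyond the scatter) lies beyond it.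

Compound 4 (`COc1cc(Nc2ncnc3c(NC(=O)Nc4ccc(Cl)c(Cl)c4)cccc23)cc(OC)c1`) keeps the same atoms but joins them differently: 3,4-dichlorophenyl in place of 2,4-dichlorophenyl on an amide-type nitrogen. It carries 3,4-dichlorophenyl in place of 2,4-dichlorophenyl on an amide-type nitrogen. Going by the values given here, no measured step makes this exact swap. Among the compounds with values here, the steps that bear on it replace the group at this same place, and even the largest, a 3.7-fold higher number from compound 1 to compound 2 (0.56 log units; beyond the scatter), is only modest. No change beyond the scatter is therefore expected in this assay, in either direction. The expected step is a 1.0-fold lower number from compound 3 to compound 4 (0.01 log units; within the scatter). The estimate for compound 4 is 3000 nM, with an expected range of 1200 nM to 8000 nM.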

Compound 4, concentration for 50% growth inhibition: 6230 nM
For compound 4 the middle estimate is 2.1-fold (0.32 log units) below the measured one; measured number inside the range.
By their numbers in this assay, from the lowest: compounds 1 and 3 (each within the scatter of the next); then compounds 4 and 2 (each within the scatter of the next).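

In this assay, rearranging the same atoms on the phenyl ring is enough to change the result: with 3,4-dichlorophenyl in place of 2,4-dichlorophenyl on the amide-type nitrogen, there is a 2.0-fold higher number from compound 3 to compound 4 (0.31 log units; beyond the scatter) and the step is modest. The 3,4-dichlorophenyl group also separates from the 2,3-dihydro-1,4-benzodioxin-6-yl group, with a 2.3-fold higher number from compound 1 to compound 4 (0.36 log units; beyond the scatter) as the step, but not from the 3,5-dimethylphenyl group, with a 1.6-fold lower number from compound 2 to compound 4 (0.21 log units; within the scatter) as the step, so the four groups now fall into two pairs. Nothing measured here accounts for the effect of this rearrangement.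

As far as these compounds go, the effect of other chlorine arrangements, such as 3,5-dichlorophenyl, or of a single chlorine, as in 4-chlorophenyl, remains open. So does the effect of a phenyl ring carrying an amine or a carboxylic acid at this place.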